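Notes on compound 4: carboxyphenyl for methylphenyl

This account rests on a few compounds, and the source may have more. Where it says the series, first, only, none or still open, it means among the compounds named here.

The series shares the core of compound 1 `c1ccc(COc2ccc(OCCOCCNC3CCCC3)cc2)cc1`; compound 2 `O=C(O)c1ccc(COc2ccc(OCCOCCNC3CCCC3)cc2)cc1` carries a carboxy and compound 3 `Cc1ccc(COc2ccc(OCCOCCNC3CCCC3)cc2)cc1` a methyl on the aromatic carbon. In a functional assay on SK-OV-3 cells (Homo sapiens) for inhibition, read by CCK-8 assay, with a stated time of 70 h (a higher number here means a weaker inhibitor, a lower number a stronger inhibitor), compound 1 gives 24800 nM and compound 3 gives 17200 nM. For compound 2 the assay reports only a limit, > 100000 nM. Compound 3 has the lowest of the two numbers; the nearest is compound 1, with a 1.4-fold lower number from compound 1 to compound 3 (0.16 log units; within the scatter), so no order between the two is claimed.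

Compound 4 `O=C(O)c1cccc(COc2ccc(OCCOCCNC3CCCC3)cc2)c1` differs from compound 3 by 3-carboxyphenyl in place of 4-methylphenyl on a saturated chain carbon bound to an oxygen on an aromatic ring. Among the compounds with values here, two measured steps bear on this: an at least 4.0-fold higher number from compound 1 to compound 2 (0.60 log units; beyond the scatter) and an at least 5.8-fold lower number from compound 2 to compound 3 (0.76 log units; beyond the scatter), both beyond the scatter and both pointing the same way, with the carboxy compound giving the higher number. The step from compound 3 to compound 4 is therefore expected to raise the number beyond the scatter, by about a 4.7-fold higher number from compound 3 to compound 4 (0.67 log units; beyond the scatter), with a fair chance that only a limit is reported again, as for compound 2 at the limit of > 100000 nM in this assay, at which 1 of the 3 values shown sits. Compound 4 is estimated at 80000 nM, between 30000 nM and 250000 nM.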

Compound 4, half-maximal inhibitory concentration: > 100000 nM
Compound 4: a limit, no number; the forecaster's own chance of this, stated with the estimate: 55%; middle value at least 1.2-fold (0.09 log units) from the limit.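

With 3-carboxyphenyl on the saturated chain carbon bound to an oxygen on an aromatic ring, compound 4 in this assay is again reported only as a limit, as compound 2 with 4-carboxyphenyl was: the limit of > 100000 nM in this assay, at which 2 of the 4 values shown sit.

The rise in the number is therefore not tied to 4-carboxyphenyl alone, with an at least 5.8-fold higher number from compound 3 to compound 4 (0.76 log units; beyond the scatter) and an at least 4.0-fold higher number from compound 1 to compound 4 (0.60 log units; beyond the scatter), both beyond the scatter. The step from compound 2 to compound 4 joins two limits and cannot be read, so no order between 3-carboxyphenyl and 4-carboxyphenyl is claimed.

The compounds shown leave open whether a methyl ester or a primary amide in place of the carboxy would stay near compound 1 and compound 3 or also reach the limit. They also leave open how 3-methylphenyl would compare with 4-methylphenyl.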